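Series notes: fluoro in place of methyl, compound 4

The compounds below may be only part of what the source reports. "The series", "measured", "known", "first", "only" and "open" are said of these compounds alone.

In a functional assay on A549 cells (Homo sapiens) for cytotoxicity, read by CCK-8 assay, with a stated time of 24 h (a lower number here means a stronger inhibitor, a higher number a weaker inhibitor), compound 1 `C/C(=C\c1cc(-c2cccnc2)co1)C(N)=O` gives 6620 nM. Compound 2 `C/C(=C\c1nc(-c2ccccc2)cs1)C(N)=O` reaches only a limit of this assay, > 50000 nM. Compound 3 `C/C(=C\c1nc(-c2ccc(C)cc2)cs1)C(N)=O` likewise reaches only a limit, > 50000 nM. Compound 3 thus stands at the limit of > 50000 nM in this assay, at which 2 of the 3 values shown sit, and the step that the two limits leave unreadable from compound 2 to compound 3 cannot be sized. Compound 4 `C/C(=C\c1nc(-c2ccc(F)cc2)cs1)C(N)=O` differs from compound 3 by fluoro in place of methyl on an aromatic carbon. No measured step covers this exchange, and the single step that comes close is itself unreadable, so no direction can be drawn from the shown values. Compound 4 is therefore expected to sit near the same limit, estimated at 60000 nM within 20000 nM to 200000 nM. The step that the limit leaves unreadable from compound 3 to compound 4 is expected to be none beyond the scatter.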

Compound 4, half-maximal inhibitory concentration: 13200 nM
Beside the measured number, compound 4's estimate is 4.5-fold (0.66 log units) above it; measured number outside the range, below it.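

In this assay, the aromatic carbon para to a large group responds to substitution: fluoro in place of methyl gives an at least 3.7-fold lower number from compound 3 to compound 4 (0.57 log units; beyond the scatter), and fluoro in place of hydrogen gives an at least 3.7-fold lower number from compound 2 to compound 4 (0.57 log units; beyond the scatter). Within the data shown here, compound 4 is the only compound on the core of compound 2 with a number rather than a limit. Both steps give only a minimum size, set by the limit: the limit of > 50000 nM in this assay, at which 2 of the 4 values shown sit.

The step for methyl in place of hydrogen cannot be read. From the compounds shown here alone, whether chloro, methoxy or an amine at this carbon would lower the number further remains open.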